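Methoxy on the Phenyl Ring of an Isoxazolidine Lactone

The source may report more compounds than this note shows. Statements on the series, on what has been measured and on what is new or still open speak of the compounds shown alone.

Measured so far:
Compound 1 `C[C@H]1CC[C@@H]2[C@@H](OC(=O)[C@]23CC(c2ccc(F)cc2)=NO3)[C@]2(C)C(=O)C=C[C@@]12O`: 1.58
Compound 2 `C[C@H]1CC[C@@H]2[C@@H](OC(=O)[C@]23CC(c2ccccc2)N(c2ccccc2)O3)[C@]2(C)C(=O)C=C[C@@]12O`: 3.19

In a physicochemical assay for lipophilicity (a lower number here means a more polar compound, a higher number a more lipophilic compound), compound 2 gives 3.19, the higher of the two numbers; compound 1 gives 1.58, and the gap between them lies beyond the scatter. Compound 3 `COc1cccc(C2C[C@@]3(ON2c2ccccc2)C(=O)O[C@@H]2[C@H]3CC[C@H](C)[C@]3(O)C=CC(=O)[C@@]23C)c1` has not yet been measured. It differs from compound 2 in one place: methoxy in place of hydrogen on an aromatic carbon. Within the data shown here, no measured pair here shows such a change, so the expectation rests on the change alone; the step of a number 0.01 log units higher from compound 2 to compound 3 (within the scatter) is expected to stay within the scatter. Compound 3 is therefore estimated at 3.2, between 2.8 and 3.6.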

Compound 3, partition coefficient: 3.25
For compound 3 the middle estimate is 0.05 log units below the measured one, within the range that was stated.
By their numbers in this assay, from the lowest: compound 1; then compounds 2 and 3 (each within the scatter of the next).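

In this assay, the change from phenyl to 3-methoxyphenyl, with methoxy in place of hydrogen on an aromatic carbon meta to a large group, gives a number 0.06 log units higher from compound 2 to compound 3 (within the scatter) and so does not move the read-out beyond the scatter. This pair is the only one here that differs in one place, and it shows that at this position the added methoxy leaves the number effectively unchanged. No measurement shown here offers an explanation for this result. From the compounds shown here alone, it remains open whether an amine or a carboxylic acid at the same position would also stay within the scatter, and whether a longer chain such as butoxy would do so.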